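The source may report more compounds than this note shows. Statements on the series, on what has been measured and on what is new or still open speak of the compounds shown alone.

In a functional assay on NCI-H146 cells (Homo sapiens) for cytotoxicity, with a stated time of 48 h, in the presence of a further agent that is not named here (a higher number here means that more compound is needed for the effect, a lower number that less compound is needed), two close relatives have been measured so far. Compound 1 `Cc1cc(S(=O)(=O)NC(=O)c2ccc(N3CCN(Cc4ccccc4-c4ccc(Cl)cc4)CC3)cc2)ccc1N[C@H](CCN(C)C)CSc1ccccc1` gives 28800 nM. Compound 2 `CN(C)CC[C@H](CSc1ccccc1)Nc1ccc(S(=O)(=O)NC(=O)c2ccc(N3CCN(Cc4ccccc4-c4ccc(Cl)cc4)CC3)cc2)cc1S(=O)(=O)C(F)(F)F` gives 39.4 nM, the lower of the two numbers, so it needs much less compound for the effect. These two differ in one place only: putting (trifluoromethyl)sulfonyl in place of methyl on an aromatic carbon gives a 730-fold lower number from compound 1 to compound 2 (2.86 log units; beyond the scatter), a large step.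

Compound 3 `CN(C)CC[C@H](CSc1ccccc1)Nc1ccc(S(=O)(=O)NC(=O)c2ccc(N3CCN(Cc4ccccc4-c4ccc(Cl)cc4)CC3)cc2)cc1OC(F)(F)F` changes that same place again, with trifluoromethoxy in place of (trifluoromethyl)sulfonyl on an aromatic carbon. Among the measured compounds shown here, this is the only measured step that bears on the change, and it shows how much the number can move at this one position. It does not show how trifluoromethoxy will behave. For the measured compounds named here, no compound with that group has been measured. The working expectation is a number somewhere between those of the two measured compounds, with compound 2 at 39.4 nM and compound 1 at 28800 nM. The expected change is a 20-fold higher number from compound 2 to compound 3 (1.31 log units; beyond the scatter), a move upward and beyond the scatter, yet smaller than the measured step. For compound 3 the estimated value is 800 nM, with an expected range from 120 nM to 6000 nM.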

Compound 3, half-maximal effective concentration: 5080 nM
Compound 3: middle estimate off by 6.4-fold (0.80 log units), on the low side; low and high end bracket the measured number.
By their numbers in this assay, from the lowest: compound 2; then compound 3; then compound 1.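

With trifluoromethoxy at this position, the number in this assay climbs most of the way back, with a 130-fold higher number from compound 2 to compound 3 (2.11 log units; beyond the scatter) against only a 5.7-fold lower number from compound 1 to compound 3 (0.75 log units; beyond the scatter) as a gain over the methyl group. Among these three compounds, the position therefore does more than separate a weak group from a strong one: trifluoromethoxy gives an intermediate number, much closer to that of methyl than to that of (trifluoromethyl)sulfonyl. Both groups in this new step carry three fluorine atoms on one carbon, so having those atoms at this place is not enough to reach the low number of compound 2, and nothing available here accounts for the large gap between the two groups.

The compounds shown leave open whether the sulfonyl unit or its fluorinated carbon matters more, and a methylsulfonyl group or a plain trifluoromethyl group at this same place would help to separate the two. Going by these compounds, it also remains open whether a group without sulfur or fluorine, such as a nitrile, would fall near methyl or near (trifluoromethyl)sulfonyl.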